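Oxadiazoline series: HEK293 cytotoxicity and a chloro-to-methyl swap

The source may report more compounds than this note shows. Statements on the series, on what has been measured and on what is new or still open speak of the compounds shown alone.

Compound 1 `Clc1ccc(C2ON=C(c3cccc(Cl)c3)O2)cc1` gives > 100000 nM, a limit of the assay.
Compound 2 `Cc1ccc(C2ON=C(c3cccc(Cl)c3)O2)cc1` gives > 100000 nM, a limit of the assay.
Compound 3 `Clc1ccc(C2=NOC(c3ccc(Cl)cc3)O2)cc1` gives > 100000 nM, a limit of the assay.

The read-out throughout is an ADME assay on HEK293 cells (Homo sapiens) for cytotoxicity, read by MTT assay, with a stated time of 44 h; a higher number here means a weaker inhibitor, a lower number a stronger inhibitor. Compound 1 and compound 2 share a core and differ by methyl in place of chloro on an aromatic carbon. The step that the two limits leave unreadable from compound 1 to compound 2 is not readable in size, because of the limit of > 100000 nM in this assay, at which 3 of the 3 values shown sit. Compound 3 carries the same atoms as compound 1 joined differently; the difference between the two cores is not broken down here. For compound 3 only a limit is known in this assay, as for the other two.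

The unmeasured compound 4 `Cc1ccc(C2ON=C(c3ccc(Cl)cc3)O2)cc1` stands to compound 3 as compound 2 stands to compound 1: the change is methyl in place of chloro on an aromatic carbon, the same change at the same kind of place. Since the change from compound 1 to compound 2 left both ends of the pair at the limit, and compound 3 itself sits at the limit, compound 4 is expected to sit there as well, with the step of a number no higher from compound 3 to compound 4 (the limit leaves the size open) expected to be within the usual scatter. For compound 4 the estimate is 100000 nM, with a range from 50000 nM to 300000 nM, and most likely the assay will again report only a limit rather than a number.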

Compound 4, half-maximal inhibitory concentration: > 100000 nM
Compound 4: a limit, no number; the forecaster's own chance of this, stated with the estimate: 90%; the middle value sits exactly at the limit.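

No size can be read for the step between compound 3 and compound 4, nor for the one between compound 1 and compound 2, because both pairs stand at a limit at both ends: the limit of > 100000 nM in this assay, at which 4 of the 4 values shown sit.

The compounds shown leave open whether methyl in place of chloro on an aromatic carbon shifts the read-out in this assay for either core, and how far the two cores differ.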